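Dropping the Methyl from Compound 3: Expected Edema Inhibition

The compounds below may be only part of what the source reports. "The series", "measured", "known", "first", "only" and "open" are said of these compounds alone.

Measured compounds:
Compound 1, `COc1ccc(C2=Nn3c(nnc3-c3cc(Cl)cc(Cl)c3Cl)SC2)cc1`: 19.4%
Compound 2, `Cc1ccc(C2=Nn3c(nnc3-c3cc(Cl)cc(Cl)c3Cl)SC2)cc1`: 19.4%
Compound 3, `Cc1ccc(-c2nn3c(-c4cc(Cl)cc(Cl)c4Cl)nnc3s2)cc1`: 22.6%

All three were tested in a functional assay on the whole organism with Rattus norvegicus as the target, read by paw edema, at a dose of 50 mg/kg by the oral route; on this read-out higher numbers stand for more inhibition at the one dose given (going by the name of the read-out) and lower numbers for less inhibition. Compound 3 shows the highest of the three numbers, but its gaps to compound 1 and to compound 2 are each within the scatter, so the three cannot be told apart on these data.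

Compound 4, `Clc1cc(Cl)c(Cl)c(-c2nnc3sc(-c4ccccc4)nn23)c1`, has not yet been measured. Compared with compound 3 the change is hydrogen in place of methyl on an aromatic carbon, on an aromatic carbon of a six-membered aromatic ring of carbon only, para to a large group; cut one bond further out, it reads 4-methylphenyl to phenyl.

Among the compounds with values here, only one measured step bears on this: no change at the digits printed from compound 1 to compound 2 (within the scatter). That step also swaps one small group for another at the same position of the shared core and left the read-out unchanged. With no other evidence, the expectation for this assay is no step beyond the scatter, in either direction. The estimated step is a number 1.6 percentage points lower from compound 3 to compound 4 (within the scatter). Compound 4 is therefore expected to give about 21%, with a likely range from 11% to 31%.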

Compound 4, a percentage reported as inhibition, in the whole organism at one dose (the size of the read-out at that dose, not a potency): 16.1%
Compound 4: the middle estimate sits 4.9 percentage points above what was measured; the measured number falls inside the stated range.
By their numbers in this assay, from the lowest: compounds 4, 1, 2 and 3 (each within the scatter of the next).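

Taking the methyl off the 4-methylphenyl group, leaving plain phenyl with hydrogen in its place, gives in this assay a step of a number 6.5 percentage points lower from compound 3 to compound 4 (within the scatter) and so does not separate the two compounds. The earlier step, no change at the digits printed from compound 1 to compound 2 (within the scatter) on the core of compound 1, only exchanged one group for another, whereas this comparison leaves the ring with no group at all at that place and still stays within the scatter. On the core of compound 3, then, the methyl is not needed to keep the read-out within the scatter of its parent, although this rests on a single pair of compounds at a single dose, and nothing available explains these numbers.

Still open, on these data alone, is whether a group of a different kind at this place, such as an amine, a carboxylic acid or a longer chain, would carry the number in this assay beyond the scatter in either direction. Also open, as far as these compounds go, is whether hydrogen at the same place on the core of compound 1 would again stay within the scatter of the methyl compound there.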